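The source may report more compounds than this note shows. Statements on the series, on what has been measured and on what is new or still open speak of the compounds shown alone.

Compound 1 `CCOC(=O)C1=C(S[C@@H]2CN[C@H](C(=O)Nc3cccc(C(=O)OCC)c3)C2)[C@H](C)[C@@H]2[C@@H]([C@@H](C)OC(=O)[C@@H](N)C(C)C)C(=O)N12` and compound 2 `CCOC(=O)c1cccc(NC(=O)[C@@H]2C[C@H](SC3=C(C(=O)O)N4C(=O)[C@H]([C@@H](C)O)[C@H]4[C@H]3C)CN2)c1` are the measured members of the series; compound 3 `CCOC(=O)C1=C(S[C@@H]2CN[C@H](C(=O)Nc3cccc(C(=O)OCC)c3)C2)[C@H](C)[C@@H]2[C@@H]([C@@H](C)OC(=O)CC)C(=O)N12` is not yet measured. In an ADME assay for metabolic stability, read by LC-MS, with a stated time of 3 h, at pH 6.5, tested at 50 uM (on this read-out higher numbers stand for a more stable compound and lower numbers for a less stable compound), compound 1 reads at a limit of the assay, > 95%. In this assay compound 2 likewise reads at a limit, > 95%. Where compound 1 stands is therefore known only as the limit of > 95% in this assay, at which 2 of the 2 values shown sit. Compound 3 differs from compound 1 by ethyl in place of 1-amino-2-methylpropyl on a carbonyl carbon. For the measured compounds named here, no step between measured compounds is available, so the step from compound 1 to compound 3 is expected to be a number at least 2 percentage points lower from compound 1 to compound 3 (that floor lies within the scatter), not beyond the scatter. Compound 3 is estimated at 93%, between 80% and 100%.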

Compound 3, percent of the compound remaining: > 95%
Compound 3: a limit, no number (the forecaster's own chance of this, stated with the estimate: 60%); middle value at least 2 percentage points away from the limit.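

In this assay the values of compound 1 and compound 3 are both limits of the assay, and no step can be read between them. Left open is whether ethyl in place of 1-amino-2-methylpropyl changes this read-out at all.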